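The source may report more compounds than this note shows. Statements on the series, on what has been measured and on what is new or still open speak of the compounds shown alone.

Measured compounds:
compound 1, `COc1cc2cc(Oc3ccc(NC(=O)Nc4cccc(C(F)(F)F)c4)cc3)c(C)nc2cc1OC`: 14000 nM
compound 2, `COc1cc2cc(Oc3ccc(NC(=O)Nc4ccc(Cl)c(C(F)(F)F)c4)cc3)c(C)nc2cc1OC`: 4810 nM

Among the measured compounds shown here, in a functional assay on K562 cells (Homo sapiens) for inhibition, read by sulforhodamine B assay, with a stated time of 48 h (a higher number here means a weaker inhibitor of growth, a lower number a stronger inhibitor of growth), compound 2 gives the lowest of the two numbers; the only measured step is a 2.9-fold lower number from compound 1 to compound 2 (0.46 log units; beyond the scatter). Compound 3, `COc1cc2cc(Oc3ccc(NC(=O)Nc4ccc(Cl)c(Cl)c4)cc3)c(C)nc2cc1OC`, differs from compound 2 by chloro in place of trifluoromethyl on an aromatic carbon. For the measured compounds named here, no measured step bears directly on this exchange, so the size of the effect cannot be read from the data, and only a small change, if any beyond the scatter, is expected. Compound 3 is therefore estimated at 6000 nM in this assay, within 2500 nM to 14000 nM, which would mean a step of a 1.2-fold higher number from compound 2 to compound 3 (0.10 log units; within the scatter).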

Compound 3, concentration for total growth inhibition: > 100000 nM
Compound 3 ended at the assay's limit; the forecaster's own chance of this, stated with the estimate: 3%; middle value at least 16-fold (1.22 log units) from the limit.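

In this assay, compound 3 gives > 100000 nM, which is a limit of the assay and not a number: the limit of > 100000 nM in this assay, at which 1 of the 3 values shown sits.

Even so, this position proves far from indifferent to its group, since exchanging trifluoromethyl for chloro, ortho to a chloro group, gives an at least 20-fold higher number from compound 2 to compound 3 (1.31 log units; beyond the scatter). The trifluoromethyl group alone also does better than the two chloro groups, with an at least 7.1-fold higher number from compound 1 to compound 3 (0.85 log units; beyond the scatter).

The compounds shown leave open how a methyl group, a methoxy group or a nitrile would behave at this position.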